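Trading a chlorophenyl tail for a pyridyl ring

The source may report more compounds than this note shows. Statements on the series, on what has been measured and on what is new or still open speak of the compounds shown alone.

Among the compounds with values here, in an assay on isolated protein for inhibition of sphingomyelin phosphodiesterase (Homo sapiens), read by fluorescence, with a stated time of 30 min (a lower number here means a stronger inhibitor, a higher number a weaker inhibitor), compound 2 `O=C(NO)c1cccc(OCc2ccc(-c3ccc(Cl)cc3)cc2)c1` gives 8960 nM, the lowest of the two numbers measured so far. Within the data shown here, its nearest neighbour is compound 1 `O=C(NO)c1cccc(OCc2ccc(-c3ccccc3)cc2)c1`, which in this assay gives 19600 nM; the single step, a 2.2-fold lower number from compound 1 to compound 2 (0.34 log units; beyond the scatter), is modest but beyond the scatter. Compound 3 `O=C(NO)c1cccc(OCc2ccc(-c3cccnc3)cc2)c1` has not been measured; it carries pyridin-3-yl in place of 4-chlorophenyl on an aromatic carbon. Among the measured compounds shown here, no measured step covers this exchange directly. For the measured compounds named here, the step of a 2.2-fold lower number from compound 1 to compound 2 (0.34 log units; beyond the scatter) bears on it only in part, since the chlorine that step brought in is lost again here, while the ring nitrogen that enters has no precedent among the two compounds at hand. The number is therefore expected to rise, roughly undoing that gain, with wide uncertainty. Compound 3 is estimated to give 20000 nM in this assay, within a range of 7000 nM to 55000 nM. The implied step, a 2.2-fold higher number from compound 2 to compound 3 (0.35 log units; beyond the scatter), is expected to be modest.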

Compound 3, half-maximal inhibitory concentration: 52300 nM
Estimate against measurement, compound 3: 2.6-fold (0.42 log units) below; low and high end bracket the measured number.
By their numbers in this assay, from the lowest: compound 2; then compound 1; then compound 3.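

In this assay, this position proves sensitive to more than the chlorine: pyridin-3-yl in place of 4-chlorophenyl gives a 5.8-fold higher number from compound 2 to compound 3 (0.77 log units; beyond the scatter), a larger change than the one the chlorine brought. The comparison with the plain phenyl ring shows that the loss of the chlorine is not the whole of it, since pyridin-3-yl in place of phenyl still gives a 2.7-fold higher number from compound 1 to compound 3 (0.43 log units; beyond the scatter), so exchanging a ring carbon for nitrogen alone moves the number upward. Nothing at hand accounts for this rise.

The compounds shown leave open whether pyridin-2-yl or pyridin-4-yl would behave as pyridin-3-yl does. They also leave open whether a fluorine, a bromine or a methoxy group in place of the chlorine on the carbon-only ring would lower the number further.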